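The source may hold more compounds than are shown below. What is called first, only, known or untested is meant among the compounds shown, and "the series" means these compounds.

In a functional assay on Jurkat cells (Homo sapiens) for antiproliferative activity, read by MTT assay, with a stated time of 48 h (on this read-out lower numbers stand for stronger inhibition and higher numbers for weaker inhibition), the three measured compounds stand as follows:

Compound 1 `O=C(/C=C/c1ccc2c(ccc[n+]2[O-])c1)c1ccc(F)cc1` gives 71.9 ug/mL.
Compound 2 `Cc1ccc(C(=O)/C=C/c2ccc3c(ccc[n+]3[O-])c2)cc1` gives 32.5 ug/mL.
Compound 3 `O=C(/C=C/c1ccc2ncccc2c1)c1ccc(F)cc1` gives 26.5 ug/mL.

Compound 3 has the lowest of the three numbers in this assay, but its nearest neighbour, compound 2, lies within the scatter of it, so the two cannot be ordered; only compound 1 sits clearly higher. Compound 4 `COc1ccc(C(=O)/C=C/c2ccc3ncccc3c2)cc1` differs from compound 3 by methoxy in place of fluoro on an aromatic carbon.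

Within the data shown here, one measured step bears on this change: a 2.2-fold lower number from compound 1 to compound 2 (0.34 log units; beyond the scatter). There, as here, a small group took the place of fluoro on an aromatic carbon of the same ring, though the incoming group was methyl rather than methoxy, and that pair carries the core of compounds 1 and 2, not the core of compound 3. Taking that step as the closest guide, a modest lowering of the number, at most about the size seen there and possibly within the scatter, is what is expected for a 1.5-fold lower number from compound 3 to compound 4 (0.17 log units; within the scatter). Compound 4 is therefore estimated at 18 ug/mL in this assay, with a range from 8 ug/mL to 40 ug/mL.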

Compound 4, half-maximal inhibitory concentration: 19.6 ug/mL
For compound 4 the middle estimate is 1.1-fold (0.04 log units) below the measured one, and the stated range covers the measured number.
By their numbers in this assay, from the lowest: compounds 4, 3 and 2 (each within the scatter of the next); then compound 1.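

In this assay the place para to a large group on the core of compound 3 now has a reading of its own: methoxy in place of fluoro gives a 1.4-fold lower number from compound 3 to compound 4 (0.13 log units; within the scatter) and so leaves the two compounds unordered. The earlier step, a 2.2-fold lower number from compound 1 to compound 2 (0.34 log units; beyond the scatter) and with methyl as the incoming group, came from the core of compound 1, so it could not show how the core of compound 3 answers at this place, where a second group now reads no differently from fluoro beyond the scatter. No measurement shown gives a reason for how this place responds.

On these data alone, whether methoxy would read the same on the core of compound 1, and methyl on the core of compound 3, stays open. The compounds shown also do not tell how an amine, a carboxylic acid or a longer chain such as ethoxy would read at this place.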